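Pyrazolyl in place of methyl on the amide nitrogen

The source may hold more compounds than are shown below. What is called first, only, known or untested is meant among the compounds shown, and "the series" means these compounds.

compound 1 `Cc1ccc(OCC(=O)N(Cc2cccs2)CC(C)C)cc1`: 900 nM
compound 2 `Cc1ccc(OCC(=O)N(Cc2cccs2)c2nccs2)cc1`: 2240 nM
compound 3 `Cc1ccc(OCC(=O)N(C)Cc2cccs2)cc1`: 400 nM

All three share one core and differ only in what sits on the amide-type nitrogen. In an assay on HEK293 cells for agonist activity at transient receptor potential cation channel subfamily M member 8 (Homo sapiens), read by fluorescence and calcium flux, with a stated time of 15 min (on this read-out lower numbers stand for an effect already at smaller amounts and higher numbers for an effect only at larger amounts of compound), compound 3 has the lowest number of the three: the step of a 2.3-fold lower number from compound 1 to compound 3 (0.35 log units; beyond the scatter) and the step of a 5.6-fold lower number from compound 2 to compound 3 (0.75 log units; beyond the scatter) both lie beyond the scatter, so compound 3 stands clearly ahead of the other two.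

Compound 4 `Cc1ccc(OCC(=O)N(Cc2cccs2)c2c(C)n[nH]c2C)cc1` differs from compound 3 by 3,5-dimethyl-1H-pyrazol-4-yl in place of methyl on an amide-type nitrogen. Going by the values given here, two measured steps bear on this. The step of a 5.6-fold lower number from compound 2 to compound 3 (0.75 log units; beyond the scatter) shows that taking a five-membered aromatic ring off this nitrogen and putting a methyl there lowered the number; compound 4 goes the other way, putting a five-membered aromatic ring back. The step of a 2.5-fold higher number from compound 1 to compound 2 (0.40 log units; beyond the scatter) likewise shows a higher number when an aromatic ring replaces a saturated chain on this nitrogen. A modest rise in this assay is therefore expected for compound 4, of about a 5.0-fold higher number from compound 3 to compound 4 (0.70 log units; beyond the scatter). Compound 4 is estimated at 2000 nM, with a likely range from 700 nM to 6000 nM.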

Compound 4, half-maximal effective concentration: 0.3 nM
Estimate against measurement, compound 4: 6700-fold (3.82 log units) above; measured number outside the range, below it.
By their numbers in this assay, from the lowest: compound 4; then compound 3; then compound 1; then compound 2.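

In this assay this amide-type nitrogen proves far more sensitive to its substituent than the first three compounds suggested: a 1300-fold lower number from compound 3 to compound 4 (3.12 log units; beyond the scatter) is a large step, and the same group also gives a 3000-fold lower number from compound 1 to compound 4 (3.48 log units; beyond the scatter) and a 7500-fold lower number from compound 2 to compound 4 (3.87 log units; beyond the scatter). An aromatic ring on this nitrogen therefore does not simply raise the number, since the five-membered ring of compound 2 gives the highest number of the four and that of compound 4 the lowest, so the identity of the ring decides the outcome. Nothing available here explains why these two rings differ so sharply.

From the compounds shown here alone, it remains open whether a plain 1H-pyrazol-4-yl, without the two methyl groups, would keep so low a number. A phenyl ring, or a pyrazole carrying a methyl on its ring nitrogen, would show how much of the step depends on this particular ring.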